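Swapping a dichlorophenyl for a chloronitrophenyl on compound 2

The source may report more compounds than this note shows. Statements on the series, on what has been measured and on what is new or still open speak of the compounds shown alone.

Measured so far:
compound 1 `COc1cc(C(=O)N/N=C/c2ccc(F)c(F)c2)cc(OC)c1OC`: 33.1%
compound 2 `COc1cc(C2=NN(C(C)=O)C(c3cc(Cl)cc(Cl)c3)O2)cc(OC)c1OC`: 0%
compound 3 `COc1cc(/C=N/NC(=O)c2cc(OC)c(OC)c(OC)c2)cc(OC)c1OC`: -5%

Three compounds have been run in a functional assay on BGC-823 cells (Homo sapiens) for antiproliferative activity, read by MTT assay, tested at 1 uM; a lower number here means a weaker effect, a higher number a stronger effect of the compound at the concentration tested. Compound 1 gives 33.1%, which stands beyond the scatter above the other two. Compound 2 gives 0%, and compound 3 gives -5%; these two numbers lie within the scatter of each other, so nothing separates them, and both sit well under compound 1. Going by the values given here, none of the three pairs differs in a single place, so no step between measured compounds can be read off; only the bare values stand side by side.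

Compound 4 `COc1cc(C2=NN(C(C)=O)C(c3ccc(Cl)c([N+](=O)[O-])c3)O2)cc(OC)c1OC` is the next compound. It differs from compound 2 in one place: 4-chloro-3-nitrophenyl in place of 3,5-dichlorophenyl on a saturated ring carbon. Nothing measured tells what exchanging one substituted phenyl for another on this saturated ring carbon does in this assay, since compound 1 and compound 3 carry a different core altogether. With compound 2 at 0% in this assay, the step from compound 2 to compound 4 is expected to be none beyond the scatter, that is a number 5 percentage points higher from compound 2 to compound 4 (within the scatter). Compound 4 is therefore estimated at 5%, with a range from -10% to 25%.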

Compound 4, a percentage reported as inhibition, at one concentration (the size of the read-out at that concentration, not a potency): -2.3%
Compound 4: the middle estimate sits 7.3 percentage points above what was measured; the measured number falls inside the stated range.
By their numbers in this assay, from the lowest: compounds 3, 4 and 2 (each within the scatter of the next); then compound 1.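

In this assay, going by these compounds alone, the exchange on this saturated ring carbon gives the first reading at this position: the step is a number 2.3 percentage points lower from compound 2 to compound 4 (within the scatter) and so does not separate 4-chloro-3-nitrophenyl from 3,5-dichlorophenyl, although the entering group has two hydrogen-bond acceptors and the leaving group has none. With compound 2 at 0% and compound 4 at -2.3% in this assay the pair shows no inhibition at the single concentration tested, so the result says only that neither of these two substituted phenyls gives a read-out on this core, not how far the position could respond to other groups. No measurement is at hand that would explain this result.

Still open, as far as these compounds go, is whether an unsubstituted phenyl, or a phenyl carrying an amine or a carboxylic acid, would give a number clear of the scatter at this ring carbon. Equally open, from the compounds shown here alone, is whether a longer chain in place of the acetyl group on the ring nitrogen would change the read-out for either of these two phenyl groups.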